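The source may hold more compounds than are shown below. What is called first, only, known or untested is meant among the compounds shown, and "the series" means these compounds.

Two members of the series carry numbers in an ADME assay on Vero cells (Chlorocebus sabaeus) for cytotoxicity, with a stated time of 7 days; on this read-out higher numbers stand for lower toxicity in this test and lower numbers for higher toxicity in this test. Compound 1 `COc1ccc2[nH]c(C(=O)N3CC(=O)N(Cc4ccccc4)[C@@H](COC(C)(C)C)C3)cc2c1` gives 78200 nM, and compound 2 `COc1ccc2[nH]c(C(=O)N3CC(=O)N(Cc4ccccc4)[C@@H](N4[C@H](C)CCC[C@@H]4C)C3)cc2c1` gives 1400 nM. Compound 2 therefore holds the lower of the two numbers, with compound 1 as its only comparator, the gap being a 56-fold lower number from compound 1 to compound 2 (1.75 log units; beyond the scatter). Compound 3 `COc1ccc2[nH]c(C(=O)N3CC(=O)N(Cc4ccccc4)[C@@H](COc4ccc(F)cc4)C3)cc2c1` awaits measurement. Relative to compound 2 the change is (4-fluorophenoxy)methyl in place of 2,6-dimethylpiperidin-1-yl on a saturated ring carbon. Going by the values given here, the single step that bears on this is a 56-fold lower number from compound 1 to compound 2 (1.75 log units; beyond the scatter), in which a (tert-butoxy)methyl group on that saturated ring carbon was replaced by 2,6-dimethylpiperidin-1-yl; compound 3 carries (4-fluorophenoxy)methyl on that carbon, a group closer in kind to the (tert-butoxy)methyl of compound 1 than to the piperidinyl of compound 2, so the step is expected to reverse most of that drop. The step of a 21-fold higher number from compound 2 to compound 3 (1.33 log units; beyond the scatter) is the expected outcome. Compound 3 is expected to give 30000 nM, with a likely range from 8000 nM to 100000 nM.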

Compound 3, half-maximal cytotoxic concentration: 33200 nM
The estimate for compound 3 lay 1.1-fold (0.04 log units) below the measured number; the measured number falls inside the stated range.
By their numbers in this assay, from the lowest: compound 2; then compound 3; then compound 1.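

In this assay, placing (4-fluorophenoxy)methyl in place of 2,6-dimethylpiperidin-1-yl on the saturated ring carbon gives a 24-fold higher number from compound 2 to compound 3 (1.38 log units; beyond the scatter), so the low number of compound 2 does not extend to this second ether side chain. Among the three compounds, the two ether side chains both stand well above the piperidinyl group, and none goes against this. Exchanging tert-butyl for 4-fluorophenyl on the oxygen has a much smaller effect, a 2.4-fold lower number from compound 1 to compound 3 (0.37 log units; beyond the scatter), although that step is still beyond the scatter. No available evidence accounts for these differences.

Still open, going by these compounds, is whether the low number of compound 2 follows the piperidine nitrogen, the ring itself or the direct attachment to the ring carbon. A cyclohexyl, diethylamino or piperidin-1-ylmethyl group at this position would separate these features.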